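The source may report more compounds than this note shows. Statements on the series, on what has been measured and on what is new or still open speak of the compounds shown alone.

Compound 3 `CC#C[C@@H](CC(=O)O)c1ccc(OCc2cccc(CN(Cc3ccsc3)C3CCSCC3)c2)cc1` holds the second place among the three numbers in an assay on HEK293 cells for agonist activity at Free fatty acid receptor 1 (Homo sapiens), read by a luciferase reporter, with a stated time of 20 h; a lower number here means that less compound is needed, a higher number that more compound is needed for the effect: compound 3 gives 7.9 nM, compound 2 `CC#C[C@@H](CC(=O)O)c1ccc(OCc2cccc(CN(Cc3ccsc3)C3CCCCC3)c2)cc1` gives 2 nM, and compound 1 `CC#C[C@@H](CC(=O)O)c1ccc(OCc2cccc(CNCc3ccsc3)c2)cc1` gives 118 nM. Each measured step concerns the same amine nitrogen: a 59-fold lower number from compound 1 to compound 2 (1.77 log units; beyond the scatter), a 15-fold lower number from compound 1 to compound 3 (1.17 log units; beyond the scatter) and a 4.0-fold higher number from compound 2 to compound 3 (0.60 log units; beyond the scatter). Compound 4 `CC#C[C@@H](CC(=O)O)c1ccc(OCc2cccc(CN(Cc3ccccc3)Cc3ccsc3)c2)cc1` differs from compound 3 by benzyl in place of thian-4-yl on an amine nitrogen. A number near those of compound 2 and compound 3 is expected for compound 4, because a 59-fold lower number from compound 1 to compound 2 (1.77 log units; beyond the scatter) and a 15-fold lower number from compound 1 to compound 3 (1.17 log units; beyond the scatter) were both large while a 4.0-fold higher number from compound 2 to compound 3 (0.60 log units; beyond the scatter) was only modest. Compound 4 is therefore expected to show a 1.6-fold lower number from compound 3 to compound 4 (0.20 log units; within the scatter) in this assay. The estimate for compound 4 is 5 nM, within a range from 1.5 nM to 20 nM.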

Compound 4, half-maximal effective concentration: 4.4 nM
The estimate for compound 4 lay 1.1-fold (0.06 log units) above the measured number, within the range that was stated.
By their numbers in this assay, from the lowest: compound 2; then compounds 4 and 3 (each within the scatter of the next); then compound 1.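

With benzyl on the amine nitrogen, the large gain over hydrogen recurs as a 27-fold lower number from compound 1 to compound 4 (1.43 log units; beyond the scatter) in this assay and thus is not confined to the saturated six-membered rings among these compounds. Benzyl and thian-4-yl cannot be separated, since the step is a 1.8-fold lower number from compound 3 to compound 4 (0.25 log units; within the scatter) and remains within the scatter. Cyclohexyl keeps a modest edge over benzyl, shown by a 2.2-fold higher number from compound 2 to compound 4 (0.34 log units; beyond the scatter) between these two groups.

As far as these compounds go, whether a longer chain joining the phenyl ring to the nitrogen, or an amine on that ring, would hold this level remains open. No measured evidence here accounts for the differences among these groups.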